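The source may report more compounds than this note shows. Statements on the series, on what has been measured and on what is new or still open speak of the compounds shown alone.

Measured so far:
compound 1 `Cc1nc(S(C)(=O)=O)ccc1Oc1ncnc(OC2CCN(C(=O)SC(C)(C)C)CC2)c1F`, 76%
compound 2 `Cc1nc(S(C)(=O)=O)ccc1Oc1ncnc(OC2CCN(C(=O)C(C)(C)F)CC2)c1F`, 74%

In a functional assay on isolated protein for inhibition of Glucose-dependent insulinotropic receptor (Rattus norvegicus), read by HTRF and cAMP accumulation (a higher number here means a larger maximal response, a lower number a smaller maximal response), compound 2 holds the lower of the two numbers, with compound 1 nearest; the step of a number 2 percentage points lower from compound 1 to compound 2 (within the scatter) lies within the scatter. Compound 3 `Cc1nc(S(C)(=O)=O)ccc1Oc1ncnc(OC2CCN(C(=O)c3noc(C(C)(C)F)n3)CC2)c1F` differs from compound 2 by a group of 9 heavy atoms (5 carbon, 2 nitrogen, 1 oxygen, 1 fluorine; one five-membered aromatic ring with 3 hetero atoms) in place of a group of 4 heavy atoms (3 carbon, 1 fluorine; no ring), on a carbonyl carbon. For the measured compounds named here, the only measured step, a number 2 percentage points lower from compound 1 to compound 2 (within the scatter), also exchanged the group on this carbonyl carbon and left the maximal response unchanged beyond the scatter, but it brought in no ring, so no measured step bears directly on the new group. The expected step is no change at the digits printed from compound 2 to compound 3 (within the scatter), within the scatter. Compound 3 is estimated at 74%, in the range 58% to 88%.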

Compound 3, largest response reached (reported as efficacy), in percent of the reference or control that the assay uses: 74%
Beside the measured number, compound 3's estimate shows no gap at the digits printed, and the stated range covers the measured number.
By their numbers in this assay, from the lowest: compounds 2, 3 and 1 (each within the scatter of the next).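

In this assay there is no change at the digits printed from compound 2 to compound 3 (within the scatter) and a number 2 percentage points lower from compound 1 to compound 3 (within the scatter) so the maximal response at this carbonyl carbon holds when a group with a five-membered aromatic ring with 3 hetero atoms enters. For the compounds shown here, earlier compounds carried only groups without a ring at this place, so this is the first sign that a ring is accepted here. Nothing measured here offers an explanation for this result.

The compounds shown leave open whether the ring would hold the response without its 1-fluoro-1-methylethyl group. They also leave open how a pyridine ring, an amine or a carboxylic acid would fare on this carbonyl carbon.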